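A few compounds are considered here, and "the series" means these few. Any claim that something is new, unique, unknown or untested is made for them only; others in the source may bear on it.

Values in a functional assay on the whole organism with Canis familiaris (Canis lupus familiaris) as the target (a lower number here means that less compound is needed, a higher number that more compound is needed for the effect), so far:
- compound 1 `CCNC(=O)[C@H]1OC(n2cnc3c(NC(CC)CC)ncnc32)[C@H](O)[C@@H]1O` gives 4 nM
- compound 2 `C=CCNC(=O)[C@H]1OC(n2cnc3c(NC(CC)CC)ncnc32)[C@H](O)[C@@H]1O` gives 0.078 nM

Compound 2 holds the lower of these two numbers. Compound 3 `CCC(CC)Nc1ncnc2c1ncn2C1O[C@H](C(=O)NC)[C@@H](O)[C@H]1O` differs from compound 2 by hydrogen in place of vinyl on a saturated chain carbon bound to an amide-type nitrogen. Among the compounds with values here, only one measured step bears on this: a 51-fold lower number from compound 1 to compound 2 (1.71 log units; beyond the scatter), where a vinyl also came in at this place. Removing the vinyl is therefore expected to give back much of that gain, towards a higher number. The expected step is a 38-fold higher number from compound 2 to compound 3 (1.59 log units; beyond the scatter). The estimate for compound 3 is 3 nM with a range from 0.4 nM to 25 nM.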

Compound 3, half-maximal effective concentration: 0.24 nM
The estimate for compound 3 lay 13-fold (1.10 log units) above the measured number; the measured number lies below the stated range.
By their numbers in this assay, from the lowest: compound 2; then compound 3; then compound 1.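

In this assay, taking the vinyl off gives a 3.1-fold higher number from compound 2 to compound 3 (0.49 log units; beyond the scatter) while hydrogen in place of methyl at the same place gives a 17-fold lower number from compound 1 to compound 3 (1.22 log units; beyond the scatter). The large gain seen with the vinyl therefore does not mean that this carbon needs a vinyl, since the methylcarbamoyl compound stays much closer to the allylcarbamoyl compound than the ethyl chain of compound 1 does. Among these three, the number does not move in one direction with chain length, and nothing measured here explains this order.

A saturated propyl chain would show whether the double bond or the chain length matters more. Going by these compounds, how a cyclopropyl group or a still longer chain behaves at this place also stays open.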